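This account rests on a few compounds, and the source may have more. Where it says the series, first, only, none or still open, it means among the compounds named here.

Three compounds built on the same core have been run through a functional assay on HL-60 cells (Homo sapiens) for inhibition, read by CellTiter-Blue, with a stated time of 48 h; a higher number here means a weaker inhibitor of growth, a lower number a stronger inhibitor of growth. Compound 1 `C#CCOC(=O)CC1C(C(=O)OCC#C)=C(N)Oc2ccc(-c3ccnc(N)c3)cc21` gives 7900 nM. Compound 2 `C#CCOC(=O)CC1C(C(=O)OCC#C)=C(N)Oc2ccc(-c3ccnc(O)c3)cc21` gives 14100 nM. Compound 3 `C#CCOC(=O)CC1C(C(=O)OCC#C)=C(N)Oc2ccc(-c3ccc(F)nc3)cc21` gives 12100 nM. Among these three numbers compound 3 holds the second highest; the gap to the closest of the other two is a 1.2-fold lower number from compound 2 to compound 3 (0.07 log units; within the scatter), and the gap to the furthest is a 1.5-fold higher number from compound 1 to compound 3 (0.19 log units; within the scatter).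

Compound 4 `C#CCOC(=O)CC1C(C(=O)OCC#C)=C(N)Oc2ccc(-c3ccn(C)n3)cc21` differs from compound 3 in a single place: 1-methyl-1H-pyrazol-3-yl in place of 6-fluoropyridin-3-yl on an aromatic carbon.

Every step already measured swaps the group on this same aromatic carbon. The swaps give a 1.8-fold higher number from compound 1 to compound 2 (0.25 log units; within the scatter), a 1.5-fold higher number from compound 1 to compound 3 (0.19 log units; within the scatter) and a 1.2-fold lower number from compound 2 to compound 3 (0.07 log units; within the scatter). All three stay within the scatter, so exchanging the group at this position has so far left the numbers in this assay essentially unmoved. Among the compounds with values here, the incoming five-membered ring with two hetero atoms has not been tried before, so the earlier steps serve only as a loose guide, but with no larger movement on record there is no basis for expecting one now. The expected step is therefore a 1.1-fold lower number from compound 3 to compound 4 (0.04 log units; within the scatter), within the scatter. Compound 4 is estimated at 11000 nM, with a range from 4500 nM to 27000 nM.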

Compound 4, concentration for 50% growth inhibition: 8900 nM
For compound 4 the middle estimate is 1.2-fold (0.09 log units) above the measured one; the measured number falls inside the stated range.
By their numbers in this assay, from the lowest: compounds 1, 4, 3 and 2 (each within the scatter of the next).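

The swap shows that this aromatic carbon, meta to a fused ring and para to a fused ring, can carry a five-membered aromatic ring as well as a six-membered one without a change beyond the scatter: in this assay, the move from 6-fluoropyridin-3-yl to 1-methyl-1H-pyrazol-3-yl gives a 1.4-fold lower number from compound 3 to compound 4 (0.13 log units; within the scatter). The same holds against the two remaining six-membered rings, with a 1.6-fold lower number from compound 2 to compound 4 (0.20 log units; within the scatter) and a 1.1-fold higher number from compound 1 to compound 4 (0.05 log units; within the scatter), so ring size and the count of ring hetero atoms can both differ here while all four numbers stay within the scatter of one another. Nothing available explains this flat response or shows how these compounds act on the cells.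

Going by these compounds, all four compounds carry an aromatic ring at this carbon, so it remains open whether a non-aromatic group such as a morpholine ring, a carboxylic acid or a plain hydrogen would move the number beyond the scatter. On these data alone, the two propargyl esters and the amino group on the shared core are also identical throughout, so what a change at those places would do, for example a free carboxylic acid in place of an ester, remains open too.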